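A few compounds are considered here, and "the series" means these few. Any claim that something is new, unique, unknown or untested is made for them only; others in the source may bear on it.

Measured compounds in a functional assay on CNE-2 cells (Homo sapiens) for cytotoxicity, read by MTT assay, with a stated time of 72 h; on this read-out lower numbers stand for stronger inhibition and higher numbers for weaker inhibition:
- compound 1, `O=C(NC(=S)NNc1ncnc2ccccc12)c1ccccc1F`, gives 4610 nM
- compound 2, `O=C(NC(=S)NNc1ncnc2ccccc12)c1ccccc1Cl`, gives 6090 nM

Within the data shown here, compound 2 stands at the higher of the two numbers measured so far in this assay, its only neighbour being compound 1, and the two differ only by a chloro in place of a fluoro on an aromatic carbon: a 1.3-fold higher number from compound 1 to compound 2 (0.12 log units; within the scatter). On these two numbers alone, compound 1 and compound 2 cannot be told apart.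

Compound 3, `Cc1ccccc1C(=O)NC(=S)NNc1ncnc2ccccc12`, is not yet measured. It differs from compound 2 by methyl in place of chloro on an aromatic carbon. Among the measured compounds shown here, the one measured step that bears on this position, the exchange of fluoro for chloro from compound 1 to compound 2, stayed within the scatter, so the series gives no sign that a change at this aromatic carbon moves the number much. The step to a methyl is therefore expected to be no larger than the scatter, with no direction favoured: a 1.0-fold lower number from compound 2 to compound 3 (0.01 log units; within the scatter). Compound 3 is accordingly estimated at 6000 nM in this assay, within a range of 2500 nM to 14000 nM.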

Compound 3, half-maximal inhibitory concentration: 5460 nM
Beside the measured number, compound 3's estimate is 1.1-fold (0.04 log units) above it, within the range that was stated.
By their numbers in this assay, from the lowest: compounds 1, 3 and 2 (each within the scatter of the next).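

In this assay, methyl at this aromatic carbon cannot be told apart from either halogen (a 1.1-fold lower number from compound 2 to compound 3 (0.05 log units; within the scatter); a 1.2-fold higher number from compound 1 to compound 3 (0.07 log units; within the scatter)). The earlier compounds shown here compared only fluoro and chloro, so they could not show whether the flat result extended beyond halogens; with methyl, a carbon group now joins them, and all three steps among the 2-substituted phenyl compounds, compound 1, compound 2 and compound 3, stay within the scatter, with no compound going against this within the set. No independent information is available to explain this lack of separation.

The three groups shown are each a single heavy atom, so it remains open whether a larger or charged substituent at this carbon, such as a longer alkyl chain, an amine or a carboxylic acid, would also leave the number in this assay unchanged, and whether hydrogen at this carbon would give a number in the same range. Also open, on these data alone, is whether fluoro, chloro and methyl would remain indistinguishable elsewhere on the ring or with the shared core altered.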